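Ethoxy in Place of Ethyl on a Carboxy Quinoline Amide

This account rests on a few compounds, and the source may have more. Where it says the series, first, only, none or still open, it means among the compounds named here.

Compound 3 `CCc1ccc2nc(C(=O)Nc3c(F)cc(-c4cccc(F)c4)cc3F)c(C)c(C(=O)O)c2c1` is the strongest of the three compounds measured in a functional assay on A-375 cells (Homo sapiens) for antiproliferative activity, read by MTT assay, with a stated time of 24 h, tested at 100 ug/mL; a higher number here means a stronger effect of the compound at the concentration tested, a lower number a weaker effect: in this assay compound 3 gives 71.3%, whereas compound 1 `CCc1ccc2nc(C(=O)Nc3c(F)cc(-c4cccc(F)c4)cc3F)c(C)c(O)c2c1` gives 47.3% and compound 2 `Cc1c(C(=O)Nc2c(F)cc(-c3cccc(F)c3)cc2F)nc2ccc(F)cc2c1O` gives 51.3%. The step of a number 24 percentage points higher from compound 1 to compound 3 (beyond the scatter) separates compound 3 from its closest relative, and the step of a number 4 percentage points higher from compound 1 to compound 2 (within the scatter) shows that exchanging the ethyl on the fused ring for fluoro changes little. The unmeasured compound 4 `CCOc1ccc2nc(C(=O)Nc3c(F)cc(-c4cccc(F)c4)cc3F)c(C)c(C(=O)O)c2c1` differs from compound 3 in one place: ethoxy in place of ethyl on an aromatic carbon. Within the data shown here, no measured step covers an ethoxy at that aromatic carbon; the only change at the same carbon is the step from compound 1 to compound 2, which stayed within the scatter. He therefore expects the step of a number 3.3 percentage points lower from compound 3 to compound 4 (within the scatter) to remain within the scatter. Compound 4 is estimated to give 68% in this assay, expected between 52% and 84%.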

Compound 4, a percentage reported as inhibition, at one concentration (the size of the read-out at that concentration, not a potency): 72.4%
Compound 4: the middle estimate sits 4.4 percentage points below what was measured; the range from low to high includes it.
By their numbers in this assay, from the lowest: compounds 1 and 2 (each within the scatter of the next); then compounds 3 and 4 (each within the scatter of the next).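

In this assay, ethoxy in place of ethyl on this aromatic carbon gives the step of a number 1.1 percentage points higher from compound 3 to compound 4 (within the scatter), so an oxygen and a hydrogen-bond acceptor enter here without a readable change in the number. Among these compounds, the earlier change at this carbon, fluoro in place of ethyl, was seen only with the hydroxy group in the shared core, whereas compound 3 and compound 4 show a change at the same carbon with carboxy present, and it too stays within the scatter. No measurement available gives a reason for this result.

The compounds shown leave open whether a longer chain such as butoxy, or an amine, on this carbon would also stay within the scatter of compound 3. They also leave open whether ethoxy would read the same way with hydroxy in place of carboxy, or with a methyl ester there.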